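A few compounds are considered here, and "the series" means these few. Any claim that something is new, unique, unknown or untested is made for them only; others in the source may bear on it.

Three compounds have so far been measured in a functional assay on A-375 cells (Homo sapiens) for antiproliferative activity, read by CCK-8 assay, with a stated time of 72 h, tested at 8 uM; a lower number here means a weaker effect, a higher number a stronger effect of the compound at the concentration tested:

Compound 1 `Nc1ccccc1NC(=O)c1ccc(CSC(=S)N2CCN(c3ccccc3)CC2)cc1` gives 88.6%.
Compound 2 `Nc1ccccc1NC(=O)c1ccc(CSC(=S)N2CCN(c3cccnc3)CC2)cc1` gives 88.8%.
Compound 3 `Nc1ccccc1NC(=O)c1ccc(CSC(=S)N2CCCc3ccccc32)cc1` gives 81.5%.

Compound 1 stands second highest of these three numbers. Its nearest neighbour is compound 2, reached by a number 0.2 percentage points higher from compound 1 to compound 2 (within the scatter), a step that lies within the scatter. Its furthest neighbour is compound 3, whose value sits a little lower, yet the two values of compound 1 and compound 3 also lie within the scatter of each other, so no order between any of the three can be claimed.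

The step now followed leads from compound 1 to compound 4 `CN1CCN(C(=S)SCc2ccc(C(=O)Nc3ccccc3N)cc2)CC1`. The change is methyl in place of phenyl on an amine nitrogen in a ring. For the measured compounds named here, the only measured step that bears on it is the exchange on the same amine nitrogen in a ring from compound 1 to compound 2, a number 0.2 percentage points higher from compound 1 to compound 2 (within the scatter), which shifted this assay by nothing beyond the scatter. Compound 3, with a different ring in that place, also stays within the scatter of compound 1. On this evidence the group on that ring nitrogen has so far mattered little, and the step of a number 4.6 percentage points lower from compound 1 to compound 4 (within the scatter) is therefore expected to stay within the scatter, if anything leaning slightly lower. Compound 4 is estimated to give 84%, in the range 68% to 92%.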

Compound 4, a percentage reported as inhibition, at one concentration (the size of the read-out at that concentration, not a potency): 91.6%
Compound 4: the middle estimate sits 7.6 percentage points below what was measured; the measured number falls inside the stated range.
By their numbers in this assay, from the lowest: compounds 3, 1, 2 and 4 (each within the scatter of the next, the first and the last beyond it).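

In this assay, the group on the amine nitrogen in a ring need not be aromatic: methyl, with 1 carbon in place of the 6 of phenyl and with no ring, gives a number 3 percentage points higher from compound 1 to compound 4 (within the scatter) and, against pyridin-3-yl, a number 2.8 percentage points higher from compound 2 to compound 4 (within the scatter) and so leaves the read-out within the scatter of both aromatic groups. For the compounds shown here, the comparison of 4-methylpiperazin-1-yl with 1,2,3,4-tetrahydroquinolin-1-yl on a thiocarbonyl carbon now gives the first step beyond the scatter, though only a modest one, with a number 10.1 percentage points higher from compound 3 to compound 4 (beyond the scatter) while compound 1 and compound 2 remain within the scatter of compound 4. No measurement shown here accounts for the result.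

These read-outs show only the size of the effect at a single concentration, and at that concentration no stronger or weaker effect can be claimed among compound 1, compound 2 and compound 4. On these data alone, it also remains open whether a hydrogen, an acetyl group or a longer chain such as hydroxyethyl on that ring nitrogen would keep the read-out within the same scatter.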